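A few compounds are considered here, and "the series" means these few. Any claim that something is new, unique, unknown or untested is made for them only; others in the source may bear on it.

Compound 1 `O=C(O)C[C@H](CCCCCCc1ccc2c(n1)NCCC2)c1cnc2ccccc2c1` and compound 2 `COc1ncc([C@@H](CCCCCCc2ccc3c(n2)NCCC3)CC(=O)O)cn1` share one core and differ only in the aromatic group attached to the chain. In an in vivo ADME assay on the whole organism (Canis lupus familiaris) for pharmacokinetics (on this read-out lower numbers stand for lower oral bioavailability and higher numbers for higher oral bioavailability), compound 1 gives 65%, while compound 2 gives 100%. The step of a number 35 percentage points higher from compound 1 to compound 2 (beyond the scatter) is the only measured one here. Compound 2 therefore holds the higher of the two numbers, and the nearest neighbour is compound 1, sitting well below it.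

Compound 3 `COc1ccc([C@@H](CCCCCCc2ccc3c(n2)NCCC3)CC(=O)O)cn1` carries the change (6-methoxypyridin-3-yl in place of 2-methoxypyrimidin-5-yl on a saturated chain carbon bound to two saturated chain carbons). Among the measured compounds shown here, only one measured step bears on this place, the swap from compound 1 to compound 2, and it was large. That step replaced a two-ring aromatic group with a small one-ring group; the change to compound 3 keeps a small one-ring group with a methoxy substituent and alters the ring itself. A step much smaller than the measured one is therefore expected: a number 15 percentage points lower from compound 2 to compound 3 (beyond the scatter), which means a modest drop or nothing beyond the scatter. For compound 3 the expected value in this assay is 85%, with a range from 60% to 100%.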

Compound 3, oral bioavailability: 49%
The estimate for compound 3 lay 36 percentage points above the measured number; measured number outside the range, below it.
By their numbers in this assay, from the lowest: compound 3; then compound 1; then compound 2.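

In this assay the group on the saturated chain carbon bound to two saturated chain carbons turns out to be very sensitive to the make-up of the ring: going from 2-methoxypyrimidin-5-yl to 6-methoxypyridin-3-yl keeps the 8 heavy atoms and the methoxy group, swaps one ring hetero atom for carbon, and gives a number 51 percentage points lower from compound 2 to compound 3 (beyond the scatter) as a large step. The two-ring quinolin-3-yl group also compares favourably, since replacing it with 6-methoxypyridin-3-yl gives a number 16 percentage points lower from compound 1 to compound 3 (beyond the scatter) as a modest step, so a small one-ring group with a methoxy substituent does not by itself bring a higher number, and compound 3 goes against any such rule. Nothing available explains why this single ring change matters so much.

The three compounds leave open whether the high number depends on the second ring nitrogen of 2-methoxypyrimidin-5-yl, on the methoxy group attached to that ring, or on both together. A methoxyphenyl group, with no nitrogen in its ring, or a pyrimidine ring carrying an amino group in place of the methoxy could help separate these possibilities.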